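Full agonist efficacy after swapping a piperidine substituent

The source may hold more compounds than are shown below. What is called first, only, known or untested is meant among the compounds shown, and "the series" means these compounds.

Measured so far:
compound 1 `c1ccc(CNCC2CCN(CCCc3c[nH]c4ccc(-n5cnnc5)cc34)CC2)cc1` — 101%
compound 2 `CC(C)=CCN(C)C1CCN(CCCc2c[nH]c3ccc(-n4cnnc4)cc23)CC1` — 115%

In a functional assay on CHO cells for activation of 5-hydroxytryptamine receptor 1D (Homo sapiens), read by GTPgammaS binding (a lower number here means a smaller maximal response, a higher number a larger maximal response), compound 2 stands highest of the two, with compound 1 nearest, and the change a number 14 percentage points higher from compound 1 to compound 2 (beyond the scatter) lies beyond the scatter. Compound 3 `c1ccc2c(c1)CCC2NCC1CCN(CCCc2c[nH]c3ccc(-n4cnnc4)cc23)CC1` differs from compound 2 by ((2,3-dihydro-1H-inden-1-yl)amino)methyl in place of methyl(3-methylbut-2-en-1-yl)amino on a saturated ring carbon. For the measured compounds named here, the only measured step, from compound 1 to compound 2, went the other way at that position and was modest; compound 3 returns to an aminomethyl group bearing a ring, closer to compound 1. A modest decrease a number 12 percentage points lower from compound 2 to compound 3 (beyond the scatter) is therefore expected. For compound 3 the estimated efficacy is 103%, in the range 85% to 120%.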

Compound 3, largest response reached (reported as efficacy), in percent of the reference or control that the assay uses: 78%
The estimate for compound 3 lay 25 percentage points above the measured number; the whole stated range lies above it.
By their numbers in this assay, from the lowest: compound 3; then compound 1; then compound 2.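

In this assay the swap gives a number 37 percentage points lower from compound 2 to compound 3 (beyond the scatter) and so this position on the saturated ring can move the maximal response widely, not just modestly. The closer comparison gives a number 23 percentage points lower from compound 1 to compound 3 (beyond the scatter) even though only benzyl on the amine nitrogen became 2,3-dihydro-1H-inden-1-yl, so changing the group on that nitrogen alone is enough to lower the response. Nothing available explains this drop.

As far as these compounds go, whether a cyclohexyl group on that nitrogen would keep the response seen with benzyl or lower it stays open.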